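Swapping a tetrazolyl-pyrrole for a methyl-oxadiazolyl-thiophene

A few compounds are considered here, and "the series" means these few. Any claim that something is new, unique, unknown or untested is made for them only; others in the source may bear on it.

Three compounds have been measured in a functional assay (Pituitary gland cell) with Rattus norvegicus as the target; a lower number here means that less compound is needed, a higher number that more compound is needed for the effect:
compound 1 `CC(C)(N)CC(=O)N[C@@H]1CCc2ccccc2N(Cc2ccc(-c3ccccc3-c3ncno3)cc2)C1=O` gives 30 nM;
compound 2 `Cc1noc(-c2ccccc2-c2ccc(CN3C(=O)[C@H](NC(=O)CC(C)(C)N)CCc4ccccc43)cc2)n1` gives 1050 nM;
compound 3 `CC(C)(N)CC(=O)N[C@@H]1CCc2ccccc2N(Cc2ccc(-n3cccc3-c3nn[nH]n3)cc2)C1=O` gives 275 nM.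

All three share the same core and differ only in the group carried on the benzyl ring. Compound 3 stands second highest of the three numbers: compound 1 is better by a 9.2-fold higher number from compound 1 to compound 3 (0.96 log units; beyond the scatter), while compound 2 is worse by a 3.8-fold lower number from compound 2 to compound 3 (0.58 log units; beyond the scatter).

Compound 4 `Cc1nnc(-c2cscc2-c2ccc(CN3C(=O)[C@H](NC(=O)CC(C)(C)N)CCc4ccccc43)cc2)o1` is the next step from compound 3. The change is 4-(5-methyl-1,3,4-oxadiazol-2-yl)thiophen-3-yl in place of 2-(2H-tetrazol-5-yl)-1H-pyrrol-1-yl on an aromatic carbon.

Going by the values given here, two measured steps bear on it. Going from compound 1 to compound 3 cost a 9.2-fold higher number from compound 1 to compound 3 (0.96 log units; beyond the scatter), so the unmethylated oxadiazolyl-aryl group was the better one. But adding a methyl to that oxadiazole, from compound 1 to compound 2, cost a 35-fold higher number from compound 1 to compound 2 (1.54 log units; beyond the scatter), a large loss. Among the compounds with values here, compound 4 carries a methylated oxadiazole on a thiophene, so it resembles compound 2 more closely than compound 1, and the exchange of phenyl for thiophene and of one oxadiazole isomer for another has no measured precedent here.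

Compound 4 is therefore expected to land near compound 2, a step of a 2.9-fold higher number from compound 3 to compound 4 (0.46 log units; beyond the scatter) in this assay. The estimate for compound 4 is 800 nM, with a likely range from 200 nM to 3200 nM.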

Compound 4, half-maximal effective concentration: 125 nM
Estimate against measurement, compound 4: 6.4-fold (0.81 log units) above, and the stated range ends above it.
By their numbers in this assay, from the lowest: compound 1; then compound 4; then compound 3; then compound 2.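

In this assay the 4-(5-methyl-1,3,4-oxadiazol-2-yl)thiophen-3-yl group improves on the tetrazolyl-pyrrole, with a 2.2-fold lower number from compound 3 to compound 4 (0.34 log units; beyond the scatter) and, against the methylated oxadiazole on phenyl, with an 8.4-fold lower number from compound 2 to compound 4 (0.92 log units; beyond the scatter) as well. A methylated oxadiazole on the benzyl ring therefore need not bring the full loss seen with compound 2, and a thiophene can carry the oxadiazole in place of a phenyl without the number rising further. The unmethylated group of compound 1 still gives the lowest number of the four, as the change to the thiophene group shows (a 4.2-fold higher number from compound 1 to compound 4 (0.62 log units; beyond the scatter)), and nothing measured here gives a reason for any of these shifts.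

The thiophene, the different arrangement of atoms in the oxadiazole and the methyl all change together in these steps, so the compounds shown leave open how much each one contributes. As far as these compounds go, it also remains open how an unsubstituted 1,3,4-oxadiazole on the thiophene, or an ethyl group or a carboxylic acid in place of its methyl, would behave in this assay at this position.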